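Removing the Methyl: Expected Stability of Compound 4

The source may report more compounds than this note shows. Statements on the series, on what has been measured and on what is new or still open speak of the compounds shown alone.

Compound 1 `CN1CCC(c2c[nH]c3cc(Nc4ccc(F)c(F)c4)ccc23)CC1` is the only entry in this set that carries a number. In an ADME assay on microsomes from liver (Mus musculus) for metabolic stability, with a stated time of 1 h (on this read-out higher numbers stand for a more stable compound and lower numbers for a less stable compound), compound 1 gives 35%. It stands alone on this read-out. In this assay compound 2 `CN1CCC(c2c[nH]c3ccc(Nc4ccc5c(C6CCNCC6)c[nH]c5n4)cc23)CC1` gives "not determined" (no result reported). In this assay compound 3 `c1cc2c(C3CCNCC3)c[nH]c2cc1Nc1ccc2[nH]cc(C3CCNCC3)c2c1` gives "not determined" (no result reported). Within the data shown here, no step between two measured compounds exists here, so the single value of compound 1 is the only anchor for any comparison.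

Compound 4 `Fc1ccc(Nc2ccc3c(C4CCNCC4)c[nH]c3c2)cc1F` differs from compound 1 in one place: hydrogen in place of methyl on an amine nitrogen in a ring. Everything else in the molecule, including both fluorine atoms and the shared core, is unchanged.

Without a measured step to lean on, the size of the step from compound 1 to compound 4 can only be expected, not read off. The expected step of a number 15 percentage points higher from compound 1 to compound 4 (beyond the scatter) is a moderate rise in the fraction remaining, though an outcome that stays within the usual scatter is also plausible. Among the measured compounds shown here, compound 4 is accordingly estimated to give 50% in this assay, with a range from 30% to 75% that reflects how little the single value of compound 1 constrains the result.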

Compound 4, percent of the compound remaining: 85%
For compound 4 the middle estimate is 35 percentage points below the measured one; the measured number lies above the stated range.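

In this assay, among these compounds, the change of hydrogen in place of methyl on an amine nitrogen in a ring gives a number 50 percentage points higher from compound 1 to compound 4 (beyond the scatter), the first measured step at this position. It shows that the passage from 1-methylpiperidin-4-yl to piperidin-4-yl, which removes one heavy atom while both fluorine atoms and the shared core stay as they were, is enough to produce a large step on this read-out, something the lone value of compound 1 could not reveal. Nothing measured here gives the reason that this single change at the ring nitrogen moves the fraction remaining so far.

The compounds shown leave open whether any other group on that nitrogen, such as an ethyl group, an acetyl group or a longer chain, would give a number closer to that of compound 1 or to that of compound 4. They also leave open whether a step of this size would recur if a chlorine atom or a methoxy group stood in place of the two fluorine atoms.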